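Aryl acrylates and vinyl ketones at thyroid hormone receptor alpha

A few compounds are considered here, and "the series" means these few. Any claim that something is new, unique, unknown or untested is made for them only; others in the source may bear on it.

Measured so far:
compound 1, `C=C(C)C(=O)c1ccc(CCCCCCC)cc1`, 52900 nM
compound 2, `C=CC(=O)c1ccc(CCCCC)cc1`, 60900 nM
compound 3, `C=CC(=O)Oc1ccc(CCC)cc1`, reported only as a limit, > 100000 nM

All three were run in an assay on isolated protein for displacement of a labelled ligand from thyroid hormone receptor alpha (Homo sapiens), read by fluorescence polarization; a higher number here means a weaker inhibitor, a lower number a stronger inhibitor. Compound 1 gives 52900 nM and compound 2 gives 60900 nM; these two values lie within the usual scatter of each other. For compound 3 the assay reports only a limit, > 100000 nM. That is where compound 3 stands: at the limit of the assay, as noted in the limit of > 100000 nM in this assay, at which 1 of the 3 values shown sits, with no number of its own.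

Compound 4, `C=CC(=O)Oc1ccc(CCCCC)cc1`, is the next member and is still to be measured. It differs from compound 3 by ethyl in place of hydrogen on a saturated chain carbon, three bonds along the chain from an aromatic carbon. Among the measured compounds shown here, no step between measured compounds is available to calibrate this change. In this assay the step from compound 3 to compound 4 is expected to run toward a lower number, but its size cannot be bounded well, since compound 3 sits at a limit; the expected step is an at least 1.1-fold lower number from compound 3 to compound 4 (0.04 log units; that floor lies within the scatter). Compound 4 is therefore estimated at 90000 nM, with a range from 40000 nM to 200000 nM, and a fair chance that the assay again returns only a limit.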

Compound 4, half-maximal inhibitory concentration: > 100000 nM
Compound 4 was reported as a limit; the forecaster's own chance of this, stated with the estimate: 45%; at least 1.1-fold (0.04 log units) between middle value and limit.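

In this assay compound 4 gives > 100000 nM, a limit of the assay, as compound 3 also does. Among the compounds shown here, with the pentyl chain held constant, (vinylcarbonyl)oxy in place of vinylcarbonyl on an aromatic carbon gives an at least 1.6-fold higher number from compound 2 to compound 4 (0.21 log units; that floor lies within the scatter), the first reading of this change, though only as a floor. The step for ethyl in place of hydrogen on the saturated chain carbon cannot be read, because both of its ends are limits: the limit of > 100000 nM in this assay, at which 2 of the 4 values shown sit.

On these data alone, whether a longer chain, such as octyl, in place of pentyl would give the esters a number of their own remains open. As far as these compounds go, the true size of the change from vinylcarbonyl to (vinylcarbonyl)oxy also remains open, as does the effect of an amine or a carboxylic acid on the chain.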